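Cyclohexyl for trimethoxyphenyl on the ring amine

The source may hold more compounds than are shown below. What is called first, only, known or untested is meant among the compounds shown, and "the series" means these compounds.

Measured so far in a functional assay on HT-1080 cells (Homo sapiens) for cytotoxicity, read by MTT assay, with a stated time of 72 h; on this read-out lower numbers stand for stronger inhibition and higher numbers for weaker inhibition:
Compound 1, `COc1ccc(Cn2nc(-c3ccccc3)c3cc(C(=N)Nc4ccc(N5CCN(C)CC5)cc4)nc(Nc4cc(OC)c(OC)c(OC)c4)c32)cc1`, gives 1200 nM.
Compound 2, `COc1cc(Nc2nc(C(=N)Nc3cccc(C(F)(F)F)c3)cc3c(-c4ccccc4)n[nH]c23)cc(OC)c1OC`, gives 6700 nM.
Compound 3, `COc1ccc(Cn2nc(-c3ccccc3)c3cc(C(=N)Nc4ccc(N5CCN(C)CC5)cc4)nc(NC4CCCCC4)c32)cc1`, gives 640 nM.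

Compound 3 arises from compound 1 by a single change, (cyclohexyl in place of 3,4,5-trimethoxyphenyl on a nitrogen on an aromatic ring). The measured result of that change is a 1.9-fold lower number from compound 1 to compound 3 (0.27 log units; within the scatter), so the two numbers cannot be told apart with confidence.

Among the measured compounds shown here, compound 2 is built on a different core from compound 1; the difference between the two cores is not broken down here, and no step is drawn between them. Compound 2 has the highest number of the three, beyond the scatter from compound 1 and from compound 3 alike.

Compound 4, `N=C(Nc1cccc(C(F)(F)F)c1)c1cc2c(-c3ccccc3)n[nH]c2c(NC2CCCCC2)n1`, is not yet measured. It differs from compound 2 by cyclohexyl in place of 3,4,5-trimethoxyphenyl on a nitrogen on an aromatic ring. The place is described in the same words as for the change from compound 1 to compound 3, so this is the same change, now carried onto the core of compound 2. For the measured compounds named here, the only evidence for its size is the one measured pair, and that pair moved within the scatter. For compound 4 the expected step is a 1.9-fold lower number from compound 2 to compound 4 (0.28 log units; within the scatter), which rests on a 1.9-fold lower number from compound 1 to compound 3 (0.27 log units; within the scatter). Compound 4 is thus estimated to give 3500 nM in this assay. The expected range for compound 4 runs from 1500 nM to 9000 nM.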

Compound 4, half-maximal inhibitory concentration: 21200 nM
For compound 4 the middle estimate is 6.1-fold (0.78 log units) below the measured one; measured number above the stated range.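

In this assay, cyclohexyl in place of 3,4,5-trimethoxyphenyl on a nitrogen on an aromatic ring gives a 3.2-fold higher number from compound 2 to compound 4 (0.50 log units; beyond the scatter), so this change does not carry from one core to the other with a fixed size or direction: the same change on two cores in this assay, a 1.9-fold lower number (0.27 log units; within the scatter) from compound 1 to compound 3 and a 3.2-fold higher number (0.50 log units; beyond the scatter) from compound 2 to compound 4, 5.9-fold (0.77 log units) apart, beyond the scatter of two such steps. On the core of compound 2, the number is lower with 3,4,5-trimethoxyphenyl than with cyclohexyl, whereas on the core of compound 1 the two groups cannot be told apart, and a step measured on one core is therefore a poor guide to the other in this series. Among the compounds shown here, this does not show which difference between the two cores matters, or why the outcome differs, and it rests on only one matched pair per core.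

The compounds shown leave open whether the core of compound 2 would respond in the same way to other groups on that nitrogen, such as an unsubstituted phenyl, a cyclopentyl or an open butyl chain. They also leave open how the step would behave on a core that differs from the core of compound 1 in one place only, for example one with a methylpiperazine-bearing phenyl and the ring hydrogen in place of the substituted benzyl group.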